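The source may hold more compounds than are shown below. What is called first, only, known or untested is meant among the compounds shown, and "the series" means these compounds.

Measured compounds in an assay on CHO-K1 cells for displacement of a labelled ligand from adenosine receptor A1 (Homo sapiens), read by scintillation counting, with a stated time of 60 min; a higher number here means a weaker inhibitor, a lower number a stronger inhibitor:
compound 1 `Nc1nc(N/N=C/c2cncs2)nc2c1ncn2[C@@H]1O[C@H](CO)[C@@H](O)[C@H]1O` gives 22 nM
compound 2 `CC(/C=N/Nc1nc(N)c2ncn([C@@H]3O[C@H](CO)[C@@H](O)[C@H]3O)c2n1)Cc1ccc(C(C)C)cc1` gives 9500 nM
compound 3 `Nc1nc(N/N=C/c2ccc(-c3ccccn3)cc2)nc2c1ncn2[C@@H]1O[C@H](CO)[C@@H](O)[C@H]1O` gives 7540 nM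

Compound 1 stands at the lowest of the three numbers, and its separation from compound 3 and from compound 2 lies beyond the usual scatter in both cases; the two larger hydrazone substituents of compounds 2 and 3 go with the two much higher numbers. Compound 4 `CCCCc1nc(/C=N/Nc2nc(N)c3ncn([C@@H]4O[C@H](CO)[C@@H](O)[C@H]4O)c3n2)c(Cl)[nH]1` has not yet been measured in this assay. It differs from compound 1 in one place: 2-butyl-5-chloro-1H-imidazol-4-yl in place of 1,3-thiazol-5-yl on a carbon with a double bond to nitrogen. Since compounds 2 and 3 show that a larger group at this position comes with a far higher number than compound 1 gives at 22 nM, a sizeable step upward, well beyond the scatter, is expected a 68-fold higher number from compound 1 to compound 4 (1.83 log units; beyond the scatter). Compound 4 is therefore estimated at 1500 nM, with a range from 200 nM to 8000 nM.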

Compound 4, inhibition constant: 12 nM
Compound 4: middle estimate off by 130-fold (2.10 log units), on the high side; measured number outside the range, below it.
By their numbers in this assay, from the lowest: compounds 4 and 1 (each within the scatter of the next); then compounds 3 and 2 (each within the scatter of the next).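

Replacing 1,3-thiazol-5-yl with 2-butyl-5-chloro-1H-imidazol-4-yl on a carbon with a double bond to nitrogen gives a 1.8-fold lower number from compound 1 to compound 4 (0.26 log units; within the scatter) in this assay. Group size alone therefore does not set the number here: the entering group has more heavy atoms than the one it replaces, yet compound 4 stays level with compound 1. Nothing available explains this result.

The compounds shown do not separate the contribution of the butyl chain from that of the chlorine. They also leave open what a longer chain or a carboxylic acid would give on this imidazole.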